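Swapping the butyl chain for ethylamino on the shared core

The source may hold more compounds than are shown below. What is called first, only, known or untested is meant among the compounds shown, and "the series" means these compounds.

Of the compounds shown here, three sharing one core have been measured in an assay on membranes from brain for displacement of a labelled ligand from Neuronal acetylcholine receptor; alpha4/beta2 (Rattus norvegicus); on this read-out lower numbers stand for stronger inhibition and higher numbers for weaker inhibition. Compound 1 `CN1CCC[C@H]1COc1cncc(C(F)(F)F)c1` gives 1.83 nM. Compound 2 `CN1CCC[C@H]1COc1cncc(Cl)c1` gives 0.6 nM. Compound 3 `CCCCc1cncc(OC[C@@H]2CCCN2C)c1` gives 0.16 nM, the lowest of the three numbers; the nearest is compound 2 and the furthest compound 1. The two steps leading to it are a 3.8-fold lower number from compound 2 to compound 3 (0.57 log units; beyond the scatter) and an 11-fold lower number from compound 1 to compound 3 (1.06 log units; beyond the scatter), while a 3.1-fold lower number from compound 1 to compound 2 (0.48 log units; beyond the scatter) separates the other pair.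

Compound 4 `CCNc1cncc(OC[C@@H]2CCCN2C)c1` differs from compound 3 in one place: ethylamino in place of butyl on an aromatic carbon. Going by the values given here, none of the measured steps replaces the chain with a group carrying a hydrogen-bond donor and acceptor, so they bear on this change only loosely. They show that a four-carbon chain in this position gave the lowest number, and that smaller or different groups gave higher ones. A higher number than that of compound 3 is therefore expected, of modest size. The expected step is a 6.3-fold higher number from compound 3 to compound 4 (0.80 log units; beyond the scatter). Compound 4 is estimated at 1 nM in this assay, within a range from 0.3 nM to 3.5 nM.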

Compound 4, inhibition constant: 3.7 nM
Estimate against measurement, compound 4: 3.7-fold (0.57 log units) below; the whole stated range lies below it.
By their numbers in this assay, from the lowest: compound 3; then compound 2; then compound 1; then compound 4.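

Ethylamino is the first group at this position in this assay to give a higher number than trifluoromethyl, with a 2.0-fold higher number from compound 1 to compound 4 (0.31 log units; beyond the scatter) and a 6.2-fold higher number from compound 2 to compound 4 (0.79 log units; beyond the scatter) showing that it also gives a higher number than chloro. The change from butyl brings a 23-fold higher number from compound 3 to compound 4 (1.36 log units; beyond the scatter) and is the largest step among the four compounds, so the chain carrying a hydrogen-bond donor and acceptor gives the highest number here, far from that of the butyl chain. No measurement shown here explains the size of this step.

The compounds shown leave open whether the higher number goes with the nitrogen attached to the ring or with the shorter chain, a question that butylamino and a propyl chain would help to separate. Going by these compounds, how a plain amino group or a longer chain such as hexyl would compare also remains open.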